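A few compounds are considered here, and "the series" means these few. Any claim that something is new, unique, unknown or untested is made for them only; others in the source may bear on it.

Measured compounds:
compound 1, `CCN(Cc1cccs1)C(=O)COc1ccc(F)cc1` — 422 nM
compound 2, `CCN(Cc1cccs1)C(=O)COc1ccc(CO)cc1` — 21900 nM
compound 3, `CCN(Cc1cccs1)C(=O)COc1ccccc1` — 1400 nM

In an assay on HEK293 cells for agonist activity at transient receptor potential cation channel subfamily M member 8 (Homo sapiens), read by fluorescence and calcium flux, with a stated time of 15 min (on this read-out lower numbers stand for an effect already at smaller amounts and higher numbers for an effect only at larger amounts of compound), compound 3 stands second highest of the three numbers; its nearest neighbour is compound 1, a 3.3-fold higher number from compound 1 to compound 3 (0.52 log units; beyond the scatter), and its furthest is compound 2, a 16-fold lower number from compound 2 to compound 3 (1.19 log units; beyond the scatter). The step to the unmeasured compound 4, `CCN(Cc1cccs1)C(=O)COc1ccc(C(F)(F)F)cc1`, is trifluoromethyl in place of hydrogen on an aromatic carbon. The measured steps on the same aromatic carbon bear on it: putting hydrogen in place of fluoro, a 3.3-fold higher number from compound 1 to compound 3 (0.52 log units; beyond the scatter), was modest, while putting hydroxymethyl in place of fluoro, a 52-fold higher number from compound 1 to compound 2 (1.72 log units; beyond the scatter), was large, and hydrogen in place of hydroxymethyl, a 16-fold lower number from compound 2 to compound 3 (1.19 log units; beyond the scatter), was also large. Trifluoromethyl shares the fluorine of compound 1 rather than the hydroxyl of compound 2, so a modest step toward a lower number in this assay is expected, roughly reversing the step from compound 1 to compound 3, though a larger group enters than left. Compound 4 is therefore estimated at 600 nM, with a range from 150 nM to 3000 nM, meaning an expected step of a 2.3-fold lower number from compound 3 to compound 4 (0.37 log units; beyond the scatter).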

Compound 4, half-maximal effective concentration: 236 nM
Compound 4: the middle estimate sits 2.5-fold (0.41 log units) above what was measured; low and high end bracket the measured number.
By their numbers in this assay, from the lowest: compounds 4 and 1 (each within the scatter of the next); then compound 3; then compound 2.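

In this assay, trifluoromethyl in place of hydrogen gives a 5.9-fold lower number from compound 3 to compound 4 (0.77 log units; beyond the scatter), so this aromatic carbon, para to a large group, accepts a group of 4 heavy atoms without the number rising. Set against hydroxymethyl, the same group gives a 93-fold lower number from compound 2 to compound 4 (1.97 log units; beyond the scatter), which shows that two groups larger than hydrogen can move the number in opposite directions here, so size alone does not set it among these compounds. Against fluoro, trifluoromethyl gives a 1.8-fold lower number from compound 1 to compound 4 (0.25 log units; within the scatter), which leaves the two groups indistinguishable in this read-out, and no measurement at hand accounts for any of these differences.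

The compounds shown leave open how a chloro, a methoxy, a nitrile, an amine or a carboxylic acid would fare on this carbon. They also leave open whether fluoro and trifluoromethyl would behave alike elsewhere on the six-membered aromatic ring.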